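Methoxycarbonyl to ethoxycarbonyl: a one-carbon extension

The source may report more compounds than this note shows. Statements on the series, on what has been measured and on what is new or still open speak of the compounds shown alone.

Compound 2 `COC(=O)c1cccc(-c2cnc(C(=O)CCc3ccc(-c4ccccc4)cc3)o2)n1` gives 1.2 nM in an assay for inhibition of Fatty-acid amide hydrolase 1 (Rattus norvegicus); a lower number here means a stronger inhibitor, a higher number a weaker inhibitor. Compound 1 `NC(=O)c1cccc(-c2cnc(C(=O)CCc3ccc(-c4ccccc4)cc3)o2)n1` gives 1.2 nM in this assay, and the step of no change at the digits printed from compound 1 to compound 2 (within the scatter) shows that compound 2 stands level with compound 1 within the scatter. Compound 3 `CCOC(=O)c1cccc(-c2cnc(C(=O)CCc3ccc(-c4ccccc4)cc3)o2)n1` is not yet measured; it differs from compound 2 by methyl in place of hydrogen on a saturated chain carbon bound to an oxygen next to a carbonyl group, read one bond further out as methoxycarbonyl to ethoxycarbonyl. Among the measured compounds shown here, no measured step covers this lengthening. For the measured compounds named here, the only step recorded, no change at the digits printed from compound 1 to compound 2 (within the scatter), swapped the group on the same carbonyl carbon and left this assay unchanged, so it is the nearest guide, though a single step is thin ground. The expected step of a 1.3-fold higher number from compound 2 to compound 3 (0.10 log units; within the scatter) is therefore none beyond the scatter. Compound 3 is estimated at 1.5 nM in this assay, with a range from 0.5 nM to 5 nM.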

Compound 3, inhibition constant: 3 nM
The estimate for compound 3 lay 2.0-fold (0.30 log units) below the measured number; low and high end bracket the measured number.
By their numbers in this assay, from the lowest: compounds 1 and 2 (each within the scatter of the next); then compound 3.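

In this assay the lengthening of methoxycarbonyl to ethoxycarbonyl gives a 2.5-fold higher number from compound 2 to compound 3 (0.40 log units; beyond the scatter) and so shows that the group on this carbonyl carbon can move the number, which no change at the digits printed from compound 1 to compound 2 (within the scatter) had not shown. Measured against the amide, ethoxy in place of amino gives a 2.5-fold higher number from compound 1 to compound 3 (0.40 log units; beyond the scatter) as a step of modest size, so the methoxy and amino groups stand level while the ethoxy group does not. Nothing available explains this loss.

The compounds shown leave open whether a longer chain on the oxygen, such as propoxy or butoxy, would raise the number further, or whether a branched isopropoxy group would behave like ethoxy. As far as these compounds go, how a carboxylic acid or a methylamide on this carbonyl carbon would stand in this assay also remains open.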